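Swapping a pyridine ring for trifluoromethyl on the shared core

The source may hold more compounds than are shown below. What is called first, only, known or untested is meant among the compounds shown, and "the series" means these compounds.

Of the compounds shown here, two built on the same core have been tested in a functional assay on LNCaP cells (Homo sapiens) for cytotoxicity, read by MTT assay; on this read-out lower numbers stand for stronger inhibition and higher numbers for weaker inhibition. Compound 1, with structure `c1cncc(-c2nnc(-c3c[nH]c4ccccc34)o2)c1`, carries a pyridin-3-yl group on the five-membered ring and gives 69400 nM in this assay. Compound 2, with structure `COc1ccc(-c2nnc(-c3c[nH]c4ccccc34)o2)cc1OC`, carries a dimethoxyphenyl group in the same place; in this assay compound 2 reaches only a limit of > 1000000 nM, so no number is known for it. Among the compounds with values here, compound 1 therefore holds the only real number, and it sits far below the limit noted as the limit of > 1000000 nM in this assay, at which 1 of the 2 values shown sits. Compound 3, with structure `FC(F)(F)c1nnc(-c2c[nH]c3ccccc23)o1`, has not been measured. It differs from compound 1 in one place: trifluoromethyl in place of pyridin-3-yl on an aromatic carbon. Within the data shown here, no measured pair shows what such a swap does here, so the expectation rests on the weak activity of compound 1 alone. A modest loss of potency, or no change beyond the scatter, seems the most likely outcome, and the expected step from compound 1 to compound 3 is a 2.2-fold higher number from compound 1 to compound 3 (0.33 log units; beyond the scatter). Compound 3 is accordingly estimated at 150000 nM, within a range from 40000 nM to 600000 nM.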

Compound 3, half-maximal inhibitory concentration: > 1000000 nM
Compound 3: no number, only a limit (the forecaster's own chance of this, stated with the estimate: 25%); middle value at least 6.6-fold (0.82 log units) away from the limit.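

In this assay, on these data alone, putting trifluoromethyl in place of pyridin-3-yl on the five-membered ring gives an at least 14-fold higher number from compound 1 to compound 3 (1.15 log units; beyond the scatter), a large step whose full size stays unknown, as it is read against a limit rather than a number. Within the data shown here, until now, dimethoxyphenyl was the only other group seen at this position, and compound 2 carries that six-membered ring yet also ends at a limit, so compound 3 shows that a group with no ring at all fares no better there, and the presence or absence of a ring does not by itself separate the two inactive compounds from compound 1. Compound 1 is now the only one of the three with a real number, and compound 2 and compound 3 cannot be ranked against each other: the limit of > 1000000 nM in this assay, at which 2 of the 3 values shown sit.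

As far as these compounds go, what remains open is which feature of pyridin-3-yl goes with the measurable activity of compound 1, for instance whether its ring nitrogen matters or the ring as a whole. A plain phenyl ring or a pyridin-4-yl group on the same carbon would help to separate these two readings.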